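This account rests on a few compounds, and the source may have more. Where it says the series, first, only, none or still open, it means among the compounds named here.

Working notes on the series. Compound 1 `COc1ccc(-c2cc(=O)cco2)cc1` carries a methoxyphenyl group on its core; compound 2 `COc1ccc(/C=C/C2CC=CC(=O)N2)cc1` carries the same methoxyphenyl on a different core, and compound 3 `COc1ccc(/C=C/C2CC=CC(=O)N2)c(OC)c1` adds a second methoxy to the aromatic ring of compound 2. In a functional assay on NCI/ADR cells (Homo sapiens) for inhibition, read by sulforhodamine B assay, with a stated time of 48 h (on this read-out lower numbers stand for stronger inhibition of growth and higher numbers for weaker inhibition of growth), compound 2 gives 842 uM. For compound 1 the assay returns only a limit, > 1230 uM, not a number. For compound 3 the assay likewise returns only a limit, > 964 uM, so compound 3 stands at the edge of what this assay resolves, and its value is one of two limits among the three values shown. Within the data shown here, the step of an at least 1.1-fold higher number from compound 2 to compound 3 (0.05 log units; that floor lies within the scatter) is the only measured step; its floor lies within the scatter, so the added methoxy shows no effect that can be separated from noise. Compound 4 `COc1cc(OC)c(OC)cc1/C=C/C1CC=CC(=O)N1` continues the same pattern: methoxy in place of hydrogen on an aromatic carbon. Among the measured compounds shown here, the only step that bears on it is an at least 1.1-fold higher number from compound 2 to compound 3 (0.05 log units; that floor lies within the scatter), which gives no direction beyond the scatter, and compound 3 already sits at a limit. The step that the limit leaves unreadable from compound 3 to compound 4 is therefore expected to be none beyond the scatter. Compound 4 is expected to give 1000 uM in this assay, within 500 uM to 2000 uM, most likely again reported only as a limit.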

Compound 4, concentration for growth inhibition (reported as GI): > 864 uM
Compound 4: only a limit was reported; the forecaster's own chance of this, stated with the estimate: 70%; the middle value lies beyond the limit too.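

Among these compounds, compound 3 and compound 4 both come back from this assay only as limits, not numbers, so no step between them can be read. The compounds shown leave open whether methoxy on the aromatic ring changes growth inhibition at all, and where the true values of compound 3 and compound 4 lie.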